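Swapping a Cyclopropyl for a Dimethylamino Chain

A few compounds are considered here, and "the series" means these few. Any claim that something is new, unique, unknown or untested is made for them only; others in the source may bear on it.

Compound 1 `COc1cccc(CN(C(=O)c2c[nH]c3nc(-c4cn[nH]c4)ccc23)C2CC2)c1` gives 6 nM in an assay on isolated protein for inhibition of Rho-associated protein kinase 2 (Homo sapiens); on this read-out higher numbers stand for weaker inhibition and lower numbers for stronger inhibition.
Compound 2 `COc1cccc(CNC(=O)c2cc3ccc(-c4cn[nH]c4)nc3n2CCCO)c1` gives 24 nM.
Compound 3 `COc1cccc(CNC(=O)c2cc3ccc(-c4cn[nH]c4)nc3n2CC2CC2)c1` gives 150 nM.

In this assay compound 3 carries the highest number of the three and so the weakest inhibition; compound 2 is nearest, as the step of a 6.3-fold higher number from compound 2 to compound 3 (0.80 log units; beyond the scatter) shows, and compound 1 is furthest away.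

Compound 4 `COc1cccc(CNC(=O)c2cc3ccc(-c4cn[nH]c4)nc3n2CCN(C)C)c1` differs from compound 3 by (dimethylamino)methyl in place of cyclopropyl on a saturated chain carbon bound to an aromatic nitrogen. For the measured compounds named here, only one measured step touches this position: a 6.3-fold higher number from compound 2 to compound 3 (0.80 log units; beyond the scatter), where a chain with a hydrogen-bond acceptor gave the lower number and the cyclopropyl the higher one. Compound 4 again brings a chain with one hydrogen-bond acceptor in place of the ring, so a step back toward the range of compound 2 is expected, namely a 4.3-fold lower number from compound 3 to compound 4 (0.63 log units; beyond the scatter). Compound 4 is therefore estimated at 35 nM, within 10 nM to 120 nM.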

Compound 4, half-maximal inhibitory concentration: 43 nM
Compound 4: middle estimate off by 1.2-fold (0.09 log units), on the low side, within the range that was stated.
By their numbers in this assay, from the lowest: compound 1; then compounds 2 and 4 (each within the scatter of the next); then compound 3.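

Replacing the cyclopropyl with (dimethylamino)methyl gives a 3.5-fold lower number from compound 3 to compound 4 (0.54 log units; beyond the scatter), so at this position the open chains of both compound 2 and compound 4 give lower numbers than the cyclopropyl of compound 3. Exchanging hydroxymethyl for dimethylamino gives a 1.8-fold higher number from compound 2 to compound 4 (0.25 log units; within the scatter), so these two chain ends cannot be told apart in this measurement. No measurement shown explains why the number shifts at this position.

Still open, going by these compounds, is whether a longer chain such as 3-(dimethylamino)propyl, a morpholine or a carboxylic acid at the chain end would hold this level.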